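This account rests on a few compounds, and the source may have more. Where it says the series, first, only, none or still open, it means among the compounds named here.

Measured compounds in a functional assay on MCF7 cells (Homo sapiens) for inhibition, read by sulforhodamine B assay; a lower number here means a stronger inhibitor, a higher number a weaker inhibitor:
compound 1, `CCc1ccc(NC2=CC(=O)c3nc4n(c3C2=O)[C@H]2OC[C@@H](O)[C@H]2OC4)cc1`: 960 nM
compound 2, `O=C1C=C(Nc2cccc(Cl)c2)C(=O)c2c1nc1n2[C@H]2OC[C@@H](O)[C@H]2OC1`: 4720 nM
compound 3, `COc1ccccc1NC1=CC(=O)c2nc3n(c2C1=O)[C@H]1OC[C@@H](O)[C@H]1OC3`: a limit only

Compound 3 stands at the weak end of the three: in this assay compound 3 gives > 4000 nM, which is a limit of the assay and not a number. Compound 1 gives the lowest number of the set. The step of a 4.9-fold higher number from compound 1 to compound 2 (0.69 log units; beyond the scatter) is beyond the scatter, as is an at least 4.1-fold higher number from compound 1 to compound 3 (0.61 log units; beyond the scatter); the step that the limit leaves unreadable from compound 2 to compound 3 cannot be read, since compound 3 sits at the limit of > 4000 nM in this assay, at which 1 of the 3 values shown sits.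

Compound 4, `O=C1C=C(N2CCCC2)C(=O)c2c1nc1n2[C@H]2OC[C@@H](O)[C@H]2OC1`, is not yet measured. It differs from compound 3 in one place: pyrrolidin-1-yl in place of (2-methoxyphenyl)amino on a double-bonded ring carbon. The change removes the aromatic ring entirely and replaces an amine bearing a hydrogen with a pyrrolidin-1-yl group. Within the data shown here, none of the measured steps covers such a change; all three vary only the substituent on an aromatic ring attached through the amine nitrogen, so they bear on the new step only in showing that this position is sensitive and that compound 3 is already at the limit.

Starting from a limit, the expectation for compound 4 is a weak value near that of compound 3, most likely again reported as a limit, the step that the limit leaves unreadable from compound 3 to compound 4 being expected around the edge of the scatter. Compound 4 is therefore estimated at 6000 nM, in the range 2500 nM to 20000 nM.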

Compound 4, half-maximal inhibitory concentration: > 16000 nM
Compound 4: only a limit was reported; the forecaster's own chance of this, stated with the estimate: 60%; at least 2.6-fold (0.42 log units) between middle value and limit.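

In this assay compound 4 gives > 16000 nM, which is a limit of the assay and not a number. The earlier compounds shown here varied only the substituent on an aromatic ring attached through the amine nitrogen, whereas pyrrolidin-1-yl on the double-bonded ring carbon removes that aromatic ring and the amine hydrogen together, and this change gives an at least 3.3-fold higher number from compound 2 to compound 4 (0.53 log units; beyond the scatter) and an at least 16-fold higher number from compound 1 to compound 4 (1.22 log units; beyond the scatter). The position therefore tolerates this replacement poorly against compound 1 and compound 2, while the steps from compound 2 to compound 3 and from compound 3 to compound 4 cannot be read, so compound 3 and compound 4 cannot be ordered.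

Compound 4 loses the aromatic ring and the amine hydrogen in one step, so the compounds shown do not separate the two losses, and a cyclopentylamino group, which would keep the amine hydrogen without the aromatic ring, is the kind of group that would divide them. On these data alone, whether a morpholin-4-yl group or a piperidin-1-yl group in this place would behave like pyrrolidin-1-yl also remains open.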